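The compounds below may be only part of what the source reports. "The series", "measured", "known", "first", "only" and "open" are said of these compounds alone.

Measured so far:
- compound 1, `O=C1N/C(=N/N=C/c2c(-c3ccc(Br)cc3)[nH]c3ccccc23)SC1CCO`: 15900 nM
- compound 2, `O=C(CC1S/C(=N\N=C\c2c(-c3ccccc3)[nH]c3ccccc23)NC1=O)c1ccccc1`: > 50000 nM

Both compounds were tested in an ADME assay on MRC5 cells (Homo sapiens) for cytotoxicity, read by fluorescence, with a stated time of 24 h; a lower number here means a stronger inhibitor, a higher number a weaker inhibitor. Compound 1, `O=C1N/C(=N/N=C/c2c(-c3ccc(Br)cc3)[nH]c3ccccc23)SC1CCO`, gives 15900 nM in this assay. Compound 2, `O=C(CC1S/C(=N\N=C\c2c(-c3ccccc3)[nH]c3ccccc23)NC1=O)c1ccccc1`, gives only a limit of the assay, > 50000 nM, and no exact number; it sits at the limit of > 50000 nM in this assay, at which 1 of the 2 values shown sits. So compound 2 stands at the top end of what this assay can report, with compound 1 the only compound that gives a measured number.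

The next compound, compound 3, `CCC1S/C(=N\N=C\c2c(-c3ccccc3)[nH]c3ccccc23)NC1=O`, has not been measured. It differs from compound 2 by methyl in place of benzoyl on a saturated chain carbon bound to a saturated ring carbon. Going by the values given here, no step between two measured compounds is available that would show what this change does in this assay. The shared core is kept, and the change is only at the saturated chain carbon bound to a saturated ring carbon. The expectation for compound 3 is therefore a step of an at least 1.1-fold lower number from compound 2 to compound 3 (0.04 log units; that floor lies within the scatter), none beyond the usual scatter, and compound 3 is estimated at 45000 nM with a range from 15000 nM to 150000 nM.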

Compound 3, half-maximal inhibitory concentration: > 50000 nM
Compound 3 gave a limit, no number; the forecaster's own chance of this, stated with the estimate: 55%; middle value at least 1.1-fold (0.04 log units) away from the limit.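

Compound 2 and compound 3 both give only a limit in this assay, not a number, so no step can be read between them: the limit of > 50000 nM in this assay, at which 2 of the 3 values shown sit.

As far as these compounds go, what methyl in place of benzoyl on a saturated chain carbon bound to a saturated ring carbon does to the number stays open.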